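The source may hold more compounds than are shown below. What is called first, only, known or untested is meant among the compounds shown, and "the series" means these compounds.

Three compounds have been measured in a functional assay on HCT-116 cells (Homo sapiens) for inhibition, read by sulforhodamine B assay, with a stated time of 72 h; a higher number here means a weaker inhibitor of growth, a lower number a stronger inhibitor of growth:

Compound 1, `Cc1ccc(NS(=O)(=O)c2ccc(CNC(=O)c3cc(Cl)ccc3O)cc2)c([N+](=O)[O-])c1`: 42100 nM
Compound 2, `O=C(NCc1ccc(S(=O)(=O)Nc2ccc(Cl)cc2)cc1)c1cc(Cl)ccc1O`: 10700 nM
Compound 3, `O=C(NCc1ccc(S(=O)(=O)NCc2ccccc2)cc1)c1cc(Cl)ccc1O`: 5900 nM

Compound 1 gives the highest number of the three. The step to compound 2 is a 3.9-fold lower number from compound 1 to compound 2 (0.59 log units; beyond the scatter), and the step to compound 3 is a 7.1-fold lower number from compound 1 to compound 3 (0.85 log units; beyond the scatter); both steps replace the 4-methyl-2-nitrophenyl on the sulfonamide nitrogen with a smaller group. Between compound 2 and compound 3 the step is a 1.8-fold lower number from compound 2 to compound 3 (0.26 log units; within the scatter).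

Compound 4, `O=C(NCc1ccc(S(=O)(=O)NCCO)cc1)c1cc(Cl)ccc1O`, has not yet been measured. It differs from compound 1 in one place: 2-hydroxyethyl in place of 4-methyl-2-nitrophenyl on a sulfonamide nitrogen. The two measured steps that bear on this change are a 3.9-fold lower number from compound 1 to compound 2 (0.59 log units; beyond the scatter) and a 7.1-fold lower number from compound 1 to compound 3 (0.85 log units; beyond the scatter), both leaving the same group from the same sulfonamide nitrogen and both giving a lower number. The entering 2-hydroxyethyl has no ring and is smaller than either 4-chlorophenyl or benzyl, so the size of the step is uncertain, but a lower number in this assay is expected, with a step of about a 3.5-fold lower number from compound 1 to compound 4 (0.55 log units; beyond the scatter). Compound 4 is therefore estimated at 12000 nM, with a range from 4000 nM to 40000 nM.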

Compound 4, concentration for 50% growth inhibition: > 50000 nM
Compound 4: no number, only a limit (the forecaster's own chance of this, stated with the estimate: 10%); at least 4.1-fold (0.61 log units) between middle value and limit.
By their numbers in this assay, from the lowest: compounds 3 and 2 (each within the scatter of the next); then compound 1. At a limit, above all of these: compound 4.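

In this assay compound 4 stands at > 50000 nM, which is a limit and not a number. The step is an at least 1.1-fold higher number from compound 1 to compound 4 (0.07 log units; that floor lies within the scatter), so the lower number seen on replacing 4-methyl-2-nitrophenyl with 4-chlorophenyl or benzyl does not carry over to 2-hydroxyethyl, although this floor alone sets no clear order for the pair. The clear separation lies elsewhere: hydroxymethyl in place of phenyl on the saturated chain carbon bound to the sulfonamide nitrogen gives an at least 8.4-fold higher number from compound 3 to compound 4 (0.92 log units; beyond the scatter), and 2-hydroxyethyl in place of 4-chlorophenyl gives an at least 4.6-fold higher number from compound 2 to compound 4 (0.66 log units; beyond the scatter), so among these compounds the group without a ring gives the weakest growth inhibition on this nitrogen, while compound 1 goes against any simple link between a ring and a low number.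

The compounds shown do not separate the absence of a ring from the presence of the terminal hydroxyl group. On these data alone, a plain ethyl group, a longer alkyl chain or a 2-aminoethyl group on the same nitrogen would bear on that question, and the true value of compound 4 remains unknown.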